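Compound 4 against the limit in the N-aryl series

The source may hold more compounds than are shown below. What is called first, only, known or untested is meant among the compounds shown, and "the series" means these compounds.

Measured in a functional assay on HEK293 cells (Homo sapiens) for cytotoxicity; a lower number here means that less compound is tolerated, a higher number that more compound is tolerated:
- compound 1 `COc1ccc([C@H]2CC(=O)N(C(=O)c3ccccc3)C2)cc1OC1CCCC1`: > 10000 nM (a limit)
- compound 2 `COc1ccc([C@H]2CC(=O)N(c3cccc(O)c3)C2)cc1OC1CCCC1`: > 10000 nM (a limit)
- compound 3 `COc1ccc([C@H]2CC(=O)N(c3cccc(N)c3C)C2)cc1OC1CCCC1`: > 10000 nM (a limit)

Compound 3 has no numerical value in this assay. Its reading of > 10000 nM is a limit. The same holds across the series, which shows (the limit of > 10000 nM in this assay, at which 3 of the 3 values shown sit).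

Compound 4 `COc1ccc([C@H]2CC(=O)N(c3ccccc3N)C2)cc1OC1CCCC1` carries 2-aminophenyl in place of 3-amino-2-methylphenyl on an amide-type nitrogen in a ring. The counted difference is 2-aminophenyl in place of 3-amino-2-methylphenyl on an amide-type nitrogen in a ring.

Three measured steps change the group at this same place: a step that the two limits leave unreadable from compound 1 to compound 2, a step that the two limits leave unreadable from compound 1 to compound 3 and a step that the two limits leave unreadable from compound 2 to compound 3. None gives a size that can be carried over to the new change. All that can be taken from them is that compound 1, compound 2 and compound 3 each end at the limit despite their different groups on that nitrogen.

In this assay, no step beyond the scatter is expected, and no direction can be assigned with confidence. The expected step is a step that the limit leaves unreadable from compound 3 to compound 4. A report of only a limit is the most likely outcome. For compound 4 the estimated value is 15000 nM, with an expected range of 7000 nM to 30000 nM.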

Compound 4, half-maximal cytotoxic concentration: > 10000 nM
Compound 4: a limit, no number; the forecaster's own chance of this, stated with the estimate: 90%; the middle value lies beyond the limit too.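

In this assay, within the data shown here, compound 4 gives > 10000 nM, a limit and not a number, so no step from compound 1, compound 2 or compound 3 to compound 4 can be read. Left open is whether the groups on the amide-type nitrogen differ at all in this assay, and whether any of them would give a number: the limit of > 10000 nM in this assay, at which 4 of the 4 values shown sit.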